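A dimethylphenyl swap on the core of compound 1

The source may hold more compounds than are shown below. What is called first, only, known or untested is meant among the compounds shown, and "the series" means these compounds.

In a functional assay on SK-OV-3 cells (Homo sapiens) for cytotoxicity (a higher number here means a weaker inhibitor of growth, a lower number a stronger inhibitor of growth), compound 1 `COc1ccc(C2=C(c3ccc(SC)cc3)CC3CCCN3C2=O)cc1O` stands at > 100000 nM which is only a limit of the assay and not a number. The related compound 2 `COc1ccc(C2=C(c3ccc(SC)cc3)CC3CCCN3C2=O)cc1OC(=O)C1CCCN1C(=O)OC(C)(C)C` gives a measured 10000 nM in this assay on the same read-out. Compound 3 `CSc1ccc(C2=C(c3ccc(C)c(C)c3)C(=O)N3CCCC3C2)cc1` carries 3,4-dimethylphenyl in place of 3-hydroxy-4-methoxyphenyl on a double-bonded ring carbon and keeps the 4-(methylsulfanyl)phenyl group. Within the data shown here, no measured step covers this change, so only a modest strengthening of uncertain size is expected, estimated as an at least 3.3-fold lower number from compound 1 to compound 3 (0.52 log units; beyond the scatter) in this assay for now. For compound 3 the estimated value is 30000 nM with an expected range of 5000 nM to 100000 nM in this assay when measured.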

Compound 3, concentration for 50% growth inhibition: 300 nM
For compound 3 the middle estimate is 100-fold (2.00 log units) above the measured one; measured number below the stated range.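

Placing 3,4-dimethylphenyl in place of 3-hydroxy-4-methoxyphenyl on a double-bonded ring carbon gives an at least 330-fold lower number from compound 1 to compound 3 (2.52 log units; beyond the scatter) in this assay, so this position responds strongly to this one change. On these data alone, the true size of the step stays open, since the value of compound 1 is a limit and not a number: the limit of > 100000 nM in this assay, at which 1 of the 3 values shown sits.

The compounds shown leave open whether the step comes from losing the hydroxy group, losing the methoxy group or gaining the methyl groups. As far as these compounds go, it is also open how an amine or a carboxylic acid on this phenyl ring would compare with compound 3.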